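Dropping One Methyl: From Compound 1 to Compound 3

A few compounds are considered here, and "the series" means these few. Any claim that something is new, unique, unknown or untested is made for them only; others in the source may bear on it.

Of the compounds shown here, two have been tested in a functional assay on PC-3 cells (Homo sapiens) for inhibition, read by sulforhodamine B assay, with a stated time of 48 h, tested at 100 uM; on this read-out lower numbers stand for less inhibition of growth and higher numbers for more inhibition of growth at the one concentration tested. Compound 1 `Cc1ccc2occ(C3N=C(c4ccccc4)SS3)c(=O)c2c1` gives 40% in this assay, the higher of the two numbers. Compound 2 `O=c1c(C(=S)Nc2ccccc2)coc2cc(Cl)c(Cl)cc12` gives 16% in this assay, a number that sits below compound 1 by more than the usual scatter. Compound 3 `O=c1c(C2N=C(c3ccccc3)SS2)coc2ccccc12` has not yet been measured. It differs from compound 1 in one place: hydrogen in place of methyl on an aromatic carbon, with the methyl leaving and a hydrogen entering on an aromatic carbon of a six-membered aromatic ring of carbon only, part of a fused system of two rings. Among the measured compounds shown here, no pair of measured compounds differs by a single change, so there is no measured step to lean on. Removing the methyl is expected to shift the read-out little, if at all, beyond the scatter, with a slight downward lean. Compound 3 is therefore estimated at 34%, within a range from 18% to 50%, meaning an expected step of a number 6 percentage points lower from compound 1 to compound 3 (within the scatter).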

Compound 3, percent growth inhibition at one concentration: 23%
Compound 3: the middle estimate sits 11 percentage points above what was measured; low and high end bracket the measured number.
By their numbers in this assay, from the lowest: compounds 2 and 3 (each within the scatter of the next); then compound 1.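

In this assay, removing the methyl from the aromatic carbon of the fused system of two rings gives a number 17 percentage points lower from compound 1 to compound 3 (beyond the scatter). Among the compounds shown here, this is the first measured single change in the set, and it shows that this position is not silent: with only one carbon atom lost, compound 3 inhibits growth less than compound 1 at the one concentration tested. No measurement shown here explains the drop.

As far as these compounds go, it remains open whether an ethyl group or a longer chain at this position would raise the number further, or whether a methoxy group or an amine could match the methyl. Also open, from the compounds shown here alone, is whether the same step would appear at other concentrations or on the core of compound 2.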